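The source may hold more compounds than are shown below. What is called first, only, known or untested is meant among the compounds shown, and "the series" means these compounds.

Compound 1 `COc1ccc([C@H]2CC(=O)N(Cc3cccc(N)c3)C2)cc1OC1CCCC1`: > 10000 nM
Compound 2 `COc1ccc([C@H]2CC(=O)N(c3cc(N)cc(N)c3)C2)cc1OC1CCCC1`: > 10000 nM
Compound 3 `COc1ccc([C@H]2CC(=O)N(c3ccccc3N)C2)cc1OC1CCCC1`: > 10000 nM

These values come from a functional assay on HEK293 cells (Homo sapiens) for cytotoxicity; on this read-out lower numbers stand for higher toxicity in this test and higher numbers for lower toxicity in this test. In this assay compound 3 gives > 10000 nM, which is a limit and not a number. Among the measured compounds shown here, the series so far stands at the limit of > 10000 nM in this assay, at which 3 of the 3 values shown sit.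

Compound 4 `COc1ccc([C@H]2CC(=O)N(c3ccc(N)cc3)C2)cc1OC1CCCC1` differs from compound 3 by 4-aminophenyl in place of 2-aminophenyl on an amide-type nitrogen in a ring, with 4-aminophenyl in place of 2-aminophenyl on an amide-type nitrogen in a ring.

The nearest measured changes are a step that the two limits leave unreadable from compound 1 to compound 3 and a step that the two limits leave unreadable from compound 2 to compound 3. Neither gives a size, so the expectation rests on the shared limit alone. The expected change is a step that the limit leaves unreadable from compound 3 to compound 4, with nothing beyond the scatter expected. Compound 4 is estimated at 12000 nM, with an expected range of 4000 nM to 30000 nM.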

Compound 4, half-maximal cytotoxic concentration: > 10000 nM
Compound 4 gave a limit, no number; the forecaster's own chance of this, stated with the estimate: 85%; the middle value does not contradict the limit.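

In this assay, among the compounds shown here, compound 4 gives > 10000 nM, a limit and not a number, so no step to it from compound 1, compound 2 or compound 3 can be read. How far these compounds differ in this assay stays open, since all sit at one limit: the limit of > 10000 nM in this assay, at which 4 of the 4 values shown sit.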